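This account rests on a few compounds, and the source may have more. Where it says the series, first, only, none or still open, it means among the compounds named here.

Compound 1, with the structure `COc1cc2ccc(=O)oc2cc1OCCCCOc1no[n+]([O-])c1S(=O)(=O)c1ccccc1`, was tested in a functional assay on MCF7 cells (Homo sapiens) for inhibition, read by MTT assay, with a stated time of 48 h (a higher number here means a weaker inhibitor, a lower number a stronger inhibitor), where compound 1 gives 3040 nM. Two related compounds were measured in the same way. Compound 2, `COc1cc2ccc(=O)oc2cc1OCCCCCOc1c[n+]([O-])on1`, gives 3850 nM in this assay, and compound 3, `COc1cc2cc(NC(C)=O)c(=O)oc2cc1OCCCOc1no[n+]([O-])c1S(=O)(=O)c1ccccc1`, gives 2400 nM in this assay. The number for compound 1 sits between those of compound 2 and compound 3, and both gaps lie within the usual scatter of repeated measurements, so the three compounds cannot be told apart on these numbers alone.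

Compound 4, `COc1cc2cc(NC(C)=O)c(=O)oc2cc1OCCCCOc1no[n+]([O-])c1S(=O)(=O)c1ccccc1`, has not yet been measured. It differs from compound 1 in one place: acetamido in place of hydrogen on an aromatic carbon. Among the compounds with values here, no pair of measured compounds differs by exactly this change, so no measured step can simply be carried over. Compound 3 carries the same acetamido group on a closely related framework, and its value of 2400 nM lies within the scatter of the value of compound 1, 3040 nM; on that basis the change from compound 1 to compound 4 is expected to be small, with no clear direction beyond the scatter. The estimate for compound 4 in this assay is therefore 2600 nM, within a range from 1200 nM to 5500 nM, which corresponds to an expected step of a 1.2-fold lower number from compound 1 to compound 4 (0.07 log units; within the scatter).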

Compound 4, half-maximal inhibitory concentration: 3440 nM
For compound 4 the middle estimate is 1.3-fold (0.12 log units) below the measured one; the range from low to high includes it.
By their numbers in this assay, from the lowest: compounds 3, 1, 4 and 2 (each within the scatter of the next).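

Within the data shown here, this is the first direct reading of this position: in this assay, acetamido in place of hydrogen on an aromatic carbon gives a 1.1-fold higher number from compound 1 to compound 4 (0.05 log units; within the scatter) and so produces no change that can be told from the scatter. The position, two atoms from the ring oxygen and ortho to a group of 1 heavy atom, therefore takes on a group of 4 heavy atoms, with 1 hydrogen-bond donor and 1 hydrogen-bond acceptor, without a clear shift in the number for this pair. Nothing measured here explains why the step is so small, and no supporting data bear on it.

The compounds shown carry only hydrogen or acetamido at this position, so it remains open whether an amine, a carboxylic acid or a longer amide chain placed there would move the number beyond the scatter. Also open, as far as these compounds go, is whether the same change would stay this small in other cell types, or with a longer chain linking the core of compound 1 to its sulfonyl-bearing ring.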